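The source may report more compounds than this note shows. Statements on the series, on what has been measured and on what is new or still open speak of the compounds shown alone.

Measured so far in a physicochemical assay for lipophilicity, using the shake flask method, in phosphate buffer, measured as octanol-water partition, with a stated time of 24 h, at pH 7.4; on this read-out higher numbers stand for higher lipophilicity and lower numbers for lower lipophilicity:

Compound 1 `Cc1cc(C2CS(=O)(=O)Oc3c2c(C2CC2)nn3-c2ccccc2Cl)ccc1Br`: 2.53
Compound 2 `COc1ccc(-c2nn(-c3ccccc3F)c3c2C(c2ccc(Br)c(C)c2)CS(=O)(=O)O3)cc1`: 2.91

Of these two numbers, the higher belongs to compound 2 at 2.91. Compound 1 lies lower, and the gap is larger than the usual scatter between repeated measurements, so it can be read as a real difference. Neither number says why the two compounds differ, and the pair does not isolate any single structural change.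

Still unmeasured is compound 3 `Cc1cc(C2CS(=O)(=O)Oc3c2c(C2CC2)nn3-c2ccccc2F)ccc1Br`. Starting from compound 2, it has cyclopropyl in place of 4-methoxyphenyl on an aromatic carbon, and the 2-fluorophenyl group stays.

Within the data shown here, no measured pair shows this exchange on its own, so the size of the step in this assay can only be expected. A fall seems likely because compound 1 with its cyclopropyl gives 2.53. The expected change is a number 0.56 log units lower from compound 2 to compound 3 (beyond the scatter). With so little data behind it, this is a rough guide and the range stays wide. For compound 3 the estimated value is 2.35, with an expected range of 2 to 2.75.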

Compound 3, partition coefficient: 2.72
For compound 3 the middle estimate is 0.37 log units below the measured one; measured number inside the range.
By their numbers in this assay, from the lowest: compounds 1, 3 and 2 (each within the scatter of the next, the first and the last beyond it).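

In this assay the exchange at this position, on an aromatic carbon of the five-membered aromatic ring, can now be read on its own with the 2-fluorophenyl group held fixed: 4-methoxyphenyl, with 8 heavy atoms, gives way to cyclopropyl, with 3, and the result is a number 0.19 log units lower from compound 2 to compound 3 (within the scatter), so this large change in the group leaves the two compounds indistinguishable on this read-out. The second exchange, fluoro in place of chloro on an aromatic carbon with cyclopropyl held fixed, gives a number 0.19 log units higher from compound 1 to compound 3 (within the scatter), so these two compounds cannot be told apart either. No supporting measurement accompanies these numbers to explain either result.

The compounds shown cover only cyclopropyl and 4-methoxyphenyl at this position, so it remains open whether an amine, a carboxylic acid or a longer chain there would shift the number beyond the scatter. As far as these compounds go, it also remains open whether fluoro in place of chloro would give a similar result with 4-methoxyphenyl in place of cyclopropyl.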